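A few compounds are considered here, and "the series" means these few. Any claim that something is new, unique, unknown or untested is made for them only; others in the source may bear on it.

In a functional assay on CCRF-CEM cells (Homo sapiens) for inhibition, with a stated time of 72 h (on this read-out lower numbers stand for stronger inhibition and higher numbers for weaker inhibition), compound 1 (`[N-]=[N+]=NCc1ncnc2c1ncn2[C@@H]1O[C@H](CO)[C@@H](O)[C@H]1O`) gives 390 nM and compound 2 (`OC[C@H]1O[C@@H](n2cnc3c(Cn4ccc5ccccc54)ncnc32)[C@H](O)[C@@H]1O`) gives 3400 nM which is the higher of these two numbers. Compound 3 (`OC[C@H]1O[C@@H](n2cnc3c(CSCc4ccccc4)ncnc32)[C@H](O)[C@@H]1O`) carries benzylsulfanyl in place of 1H-indol-1-yl on a saturated chain carbon bound to an aromatic carbon. Among the compounds with values here, only one measured step bears on this place: an 8.7-fold higher number from compound 1 to compound 2 (0.94 log units; beyond the scatter) and it was modest. With so little evidence, a smaller step toward a lower number is expected in this assay and the expected change is a 1.9-fold lower number from compound 2 to compound 3 (0.28 log units; within the scatter) for now. Compound 3 is estimated at 1800 nM with 400 nM to 6000 nM as the expected range.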

Compound 3, half-maximal inhibitory concentration: 9200 nM
Beside the measured number, compound 3's estimate is 5.1-fold (0.71 log units) below it; the whole stated range lies below it.
By their numbers in this assay, from the lowest: compound 1; then compound 2; then compound 3.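

In this assay, benzylsulfanyl in place of 1H-indol-1-yl on this saturated chain carbon gives a 2.7-fold higher number from compound 2 to compound 3 (0.43 log units; beyond the scatter), so the two ring-bearing groups are not interchangeable here, even though both weaken inhibition relative to azido. Benzylsulfanyl in place of azido gives a 24-fold higher number from compound 1 to compound 3 (1.37 log units; beyond the scatter), which widens the spread at this one place and leaves azido with the lowest number of the three. Nothing available explains these differences. Going by these compounds, whether an amine, a carboxylic acid or a plain alkyl chain at this place would match azido remains open.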